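Aryl ether variation at the phenoxy position of the series

The compounds below may be only part of what the source reports. "The series", "measured", "known", "first", "only" and "open" are said of these compounds alone.

Compound 2 `Cc1nn(C)c(Oc2ccc(F)c(F)c2)c1/C=N\CCCCCCOc1cc2oc(=O)cc(C)c2cc1Cl` carries a 3,4-difluorophenyl group on an oxygen on an aromatic ring. In a functional assay on U-87MG ATCC cells for antiproliferative activity against U-87 MG (Homo sapiens), read by MTT assay, with a stated time of 72 h (on this read-out higher numbers stand for weaker inhibition and lower numbers for stronger inhibition), compound 2 gives > 25000 nM, which is a limit of the assay and not a number. Compound 1 `Cc1nn(C)c(Oc2ccccc2F)c1/C=N\CCCCCCOc1cc2oc(=O)cc(C)c2cc1Cl` differs from compound 2 by a 2-fluorophenyl group in that place. In this assay compound 1 gives > 25000 nM, again a limit. The step that the two limits leave unreadable from compound 1 to compound 2 is therefore unreadable, with both values sitting at the limit of > 25000 nM in this assay, at which 2 of the 2 values shown sit. Compound 3 `Cc1nn(C)c(Oc2ccc(I)cc2)c1/C=N\CCCCCCOc1cc2oc(=O)cc(C)c2cc1Cl` has not yet been measured. It differs from compound 2 by 4-iodophenyl in place of 3,4-difluorophenyl on an oxygen on an aromatic ring. For the measured compounds named here, the one measured step concerns the same position but yields no readable size, so it gives no direction for the change to 4-iodophenyl. With both neighbours at the limit, compound 3 is expected to remain at the limit as well. The estimate for compound 3 in this assay is 35000 nM, within 12000 nM to 100000 nM. The expected step is a step that the limit leaves unreadable from compound 2 to compound 3.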

Compound 3, half-maximal inhibitory concentration: 16800 nM
Compound 3: the middle estimate sits 2.1-fold (0.32 log units) above what was measured; the range from low to high includes it.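

With 4-iodophenyl on an oxygen on an aromatic ring, this position gives a readable number in this assay for the first time among the compounds shown. The change reads as an at least 1.4-fold lower number from compound 2 to compound 3 (0.17 log units; that floor lies within the scatter), and as an at least 1.4-fold lower number from compound 1 to compound 3 (0.17 log units; that floor lies within the scatter); each is only a floor set by a limit at the starting compound, so a real gain over either fluorinated neighbour is not established. The step between those two neighbours cannot be read, and both remain limits: the limit of > 25000 nM in this assay, at which 2 of the 3 values shown sit.

Going by these compounds, the true distance of compound 3 from compound 1 and compound 2 remains open. On these data alone, it is also open whether a 4-bromophenyl, 4-chlorophenyl or 4-methoxyphenyl group at this position would give a readable number or stay at the limit, so nothing yet ties the readable value to iodine.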